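This account rests on a few compounds, and the source may have more. Where it says the series, first, only, none or still open, it means among the compounds named here.

Measured so far in an ADME assay on BHK-21 cells (Mesocricetus auratus) for cytotoxicity, read by MTT assay, with a stated time of 72 h; a lower number here means that less compound is tolerated, a higher number that more compound is tolerated:
- compound 1 `Cc1cccc(C2CC(c3ccc(Oc4ccccc4)cc3)=NN2c2ccc(S(N)(=O)=O)cc2)c1`: 8000 nM
- compound 2 `Cc1ccccc1C1CC(c2ccc(Oc3ccccc3)cc2)=NN1c1ccc(S(N)(=O)=O)cc1`: 7000 nM

Among the compounds with values here, compound 2, at 7000 nM, lies within the scatter of compound 1, at 8000 nM, so the series so far offers a single level and no ranking.

The next structure is compound 3 `NS(=O)(=O)c1ccc(N2N=C(c3ccc(Oc4ccccc4)cc3)CC2c2ccccc2F)cc1`, which keeps the core of compound 2. The difference is fluoro in place of methyl on an aromatic carbon. In words, this is fluoro in place of methyl on an aromatic carbon, ortho to a large group, or 2-methylphenyl to 2-fluorophenyl.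

Within the data shown here, only one measured step bears on this, and only indirectly: a 1.1-fold lower number from compound 1 to compound 2 (0.06 log units; within the scatter), with 2-methylphenyl in place of 3-methylphenyl. It stays within the scatter. Among the measured compounds shown here, no measured compound carries fluoro, so the effect of this exchange has not been tested directly. With so little evidence, no step beyond the scatter is expected in this assay, and no direction is favoured. The expected step is no change at the digits printed from compound 2 to compound 3 (within the scatter).

For compound 3 the estimated value is 7000 nM, with an expected range of 3000 nM to 15000 nM.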

Compound 3, half-maximal cytotoxic concentration: 32000 nM
Estimate against measurement, compound 3: 4.6-fold (0.66 log units) below; the whole stated range lies below it.
By their numbers in this assay, from the lowest: compounds 2 and 1 (each within the scatter of the next); then compound 3.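

At the phenyl group on the saturated ring carbon, the exchange of methyl for fluoro gives a readable change in this assay (a 4.6-fold higher number from compound 2 to compound 3 (0.66 log units; beyond the scatter)), whereas the earlier change of methyl placement stayed within the scatter (a 1.1-fold lower number from compound 1 to compound 2 (0.06 log units; within the scatter)). The comparison with the other methyl compound runs the same way (a 4.0-fold higher number from compound 1 to compound 3 (0.60 log units; beyond the scatter)), so among these three compounds 2-fluorophenyl stands apart from both 2-methylphenyl and 3-methylphenyl, with more compound tolerated in this assay. No measurement in hand accounts for this separation, which remains an observation on three compounds that share the same core.

The compounds shown leave open whether the higher number follows from fluoro itself or from the loss of methyl, a question that an unsubstituted phenyl, a chloro group or a methoxy group in this place would help to settle. Also open, from the compounds shown here alone, is whether 3-fluorophenyl would match 2-fluorophenyl, given that the two methylphenyl compounds lie within the scatter of each other.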